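Cytotoxicity notes: nitrile for bromine in the diamine series

The compounds below may be only part of what the source reports. "The series", "measured", "known", "first", "only" and "open" are said of these compounds alone.

The series is followed in an ADME assay on H9 cells (Homo sapiens) for cytotoxicity, read by XTT assay, with a stated time of 6 days; a higher number here means that more compound is tolerated, a lower number that less compound is tolerated. Compound 1 `Cc1cc(Br)cc(C)c1Oc1cc(Nc2ccc(C#N)cc2)c(N)cc1N` gives 38400 nM in this assay. Compound 2 `COc1ccc(Nc2cc(Oc3c(C)cc(Br)cc3C)c([N+](=O)[O-])cc2[N+](=O)[O-])cc1` gives 51200 nM, and compound 3 `Cc1cc(C=O)cc(C)c1Oc1cc(Nc2ccc(C#N)cc2)c([N+](=O)[O-])cc1[N+](=O)[O-]` gives 57900 nM. Within the data shown here, the number for compound 1 lies within the usual scatter of the numbers for compound 2 and for compound 3, so the measurements made so far do not separate the compounds from one another, and no step between compounds differing in a single place is available.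

Compound 4 `Cc1cc(C#N)cc(C)c1Oc1cc(Nc2ccc(C#N)cc2)c(N)cc1N` is not yet measured. It differs from compound 1 as follows: cyano in place of bromo on an aromatic carbon.

Among the measured compounds shown here, with no single-place step to draw on, the expectation rests on the spread of the measured numbers alone, which is narrow. The step from compound 1 to compound 4 is expected to stay within the scatter, with a 1.0-fold higher number from compound 1 to compound 4 (0.02 log units; within the scatter) as the estimate of its size. Compound 4 is therefore expected to give about 40000 nM in this assay, within a range from 15000 nM to 100000 nM.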

Compound 4, half-maximal cytotoxic concentration: 51000 nM
Compound 4: middle estimate off by 1.3-fold (0.11 log units), on the low side; the range from low to high includes it.
By their numbers in this assay, from the lowest: compounds 1, 4, 2 and 3 (each within the scatter of the next).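

In this assay, among these compounds, replacing bromo with cyano on this aromatic carbon provides the first single-place step, a 1.3-fold higher number from compound 1 to compound 4 (0.12 log units; within the scatter). At this position, meta to two methyl groups and para to a large group, the step therefore does not separate bromo from cyano. The earlier compounds shown here could not provide this finding. Among the compounds shown here, no pair among them differed in one place. No measured evidence on the reason for this result is available.

Going by these compounds, whether a carboxylic acid or a longer alkyl chain at the same position would also stay within the scatter remains open. A single step also leaves open whether cyano in place of bromo would read the same way on a core other than that of compound 1.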